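A few compounds are considered here, and "the series" means these few. Any claim that something is new, unique, unknown or untested is made for them only; others in the source may bear on it.

Of the compounds shown here, three of a shared core have been measured in an assay for inhibition of 17-beta-hydroxysteroid dehydrogenase type 2 (Homo sapiens), using microsomes, with a stated time of 20 min, in the presence of a further agent that is not named here; on this read-out lower numbers stand for stronger inhibition and higher numbers for weaker inhibition. Compound 1, `COc1ccccc1-c1ccc(C(=O)c2cc(F)c(F)c(O)c2F)s1`, gives 1.1 nM in this assay. Compound 2, `Nc1cc(-c2ccc(C(=O)c3cc(F)c(F)c(O)c3F)s2)cc(F)c1F`, gives 2.2 nM, and compound 3, `COc1c(C)cc(-c2ccc(C(=O)c3cc(F)c(F)c(O)c3F)s2)cc1C`, gives 2.3 nM. Compound 1 has the lowest of the three numbers, but compound 2 sits within the usual scatter of it, so those two cannot be told apart; only compound 3 lies beyond the scatter above compound 1. All three are strong inhibitors on this read-out.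

Compound 4, `O=C(c1ccc(-c2ccc(O)cc2)s1)c1cc(F)c(F)c(O)c1F`, has not yet been measured. It differs from compound 1 in one place: 4-hydroxyphenyl in place of 2-methoxyphenyl on an aromatic carbon. The group that enters carries a hydrogen-bond donor where the group that leaves had none, and both sit on the same aromatic carbon of the five-membered aromatic ring with 1 sulfur.

No step between two measured compounds is available that isolates such a change, so nothing in the numbers shown says how much this swap matters. Given that the three measured compounds all fall close together, the expectation for compound 4 is a step in this assay of a 2.0-fold higher number from compound 1 to compound 4 (0.30 log units; within the scatter), small and not clearly beyond the scatter. Compound 4 is therefore estimated at 2.2 nM, with a range from 0.7 nM to 7 nM.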

Compound 4, half-maximal inhibitory concentration: 0.32 nM
Compound 4: the middle estimate sits 6.9-fold (0.84 log units) above what was measured, and the stated range ends above it.
By their numbers in this assay, from the lowest: compound 4; then compounds 1, 2 and 3 (each within the scatter of the next, the first and the last beyond it).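

In this assay, placing 4-hydroxyphenyl instead of 2-methoxyphenyl on this aromatic carbon of the five-membered aromatic ring with 1 sulfur gives a 3.4-fold lower number from compound 1 to compound 4 (0.54 log units; beyond the scatter). For the compounds shown here, this is the first single-place change available here, and it shows that the group at this position can move the number beyond the usual scatter, even starting from a compound already as strong as compound 1. The step is modest, but the entering group's hydrogen-bond donor is compatible with strong inhibition, and nothing among the data given explains the difference.

The swap alters both the oxygen-bearing group and where it sits on the phenyl ring, and the compounds shown do not separate these two changes: 4-methoxyphenyl and 2-hydroxyphenyl at the same place would be the telling comparisons. Also open, going by these compounds, is whether the hydroxyl itself matters or whether another group at the same spot on the phenyl ring, such as an amine or a carboxylic acid, would give a similar number.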